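Saturating the alkyne: propargyl to propyl on the ether

The source may report more compounds than this note shows. Statements on the series, on what has been measured and on what is new or still open speak of the compounds shown alone.

Three compounds share one core, an aryl amide whose ether bears a short unsaturated chain. Compound 1 `C=CCOc1ccc(C(=O)Nc2cccc(C)n2)cc1` carries an allyl group and in an in vitro assay on HEK-tsA201 cells for antagonist activity at Neuronal acetylcholine receptor; alpha3/beta4 (Homo sapiens), read by fluorescence and calcium flux (on this read-out lower numbers stand for stronger inhibition and higher numbers for weaker inhibition), compound 1 gives 31700 nM. Compound 2 `C=C(C)COc1ccc(C(=O)Nc2cccc(C)n2)cc1` has a methyl added to that chain, and in this assay compound 2 gives 24700 nM. Compound 3 `C#CCOc1ccc(C(=O)Nc2cccc(C)n2)cc1` carries a propargyl group, and in this assay compound 3 gives 21700 nM, the lowest of the three numbers, though its separation from compound 2 and from compound 1 lies within the scatter.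

Compound 4 `CCCOc1ccc(C(=O)Nc2cccc(C)n2)cc1` is the next variation: ethyl in place of ethynyl on a saturated chain carbon bound to an oxygen on an aromatic ring. Going by the values given here, the steps that bear on it are those at the same place, a 1.5-fold lower number from compound 1 to compound 3 (0.16 log units; within the scatter) and a 1.1-fold lower number from compound 2 to compound 3 (0.06 log units; within the scatter), both within the scatter, as is a 1.3-fold lower number from compound 1 to compound 2 (0.11 log units; within the scatter). Trading one unsaturated two-carbon group for another has therefore moved nothing measurable here, so no step beyond the scatter is expected for compound 4, in either direction. Compound 4 is estimated at 25000 nM, with a range of 12000 nM to 50000 nM, which means an expected step of a 1.2-fold higher number from compound 3 to compound 4 (0.06 log units; within the scatter).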

Compound 4, half-maximal inhibitory concentration: 11100 nM
Compound 4: middle estimate off by 2.3-fold (0.35 log units), on the high side, outside the stated range (below it).
By their numbers in this assay, from the lowest: compounds 4, 3, 2 and 1 (each within the scatter of the next, the first and the last beyond it).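

Going by these compounds alone, at this place on the ether, the saturated propyl chain of compound 4 is the first group to stand apart from any other, with a 2.2-fold lower number from compound 2 to compound 4 (0.35 log units; beyond the scatter) and a 2.9-fold lower number from compound 1 to compound 4 (0.46 log units; beyond the scatter), both modest. Against the propargyl group, the same kind of change gives a 2.0-fold lower number from compound 3 to compound 4 (0.29 log units; within the scatter), so the propyl chain separates from the two chains with a double bond but not from the one with a triple bond. In this assay, then, a multiple bond in this chain is not needed to reach the lowest number in the set, and nothing available explains the pattern.

Still open, going by these compounds, is whether a longer chain such as butyl, or a branched one such as isopropyl, would lower the number further or raise it again. What a chain carrying an amine would do is open too.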